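Bromo for Methoxy in a Weak Amide Series

The source may hold more compounds than are shown below. What is called first, only, known or untested is meant among the compounds shown, and "the series" means these compounds.

Compound 1, `O=C(Nc1ccc(Oc2ccnc3[nH]ccc23)cc1)c1nn(-c2ccc(Br)cc2)ccc1=O`, gives 7890 nM in a functional assay on MCF7 cells (Homo sapiens) for cytotoxicity, read by MTT assay, with a stated time of 72 h; a higher number here means a weaker inhibitor, a lower number a stronger inhibitor.
Compound 2, `Cn1ccc2c(Oc3ccc(NC(=O)c4nn(-c5ccc(Cl)cc5)ccc4=O)cc3)ccnc21`, gives > 60000 nM.
Compound 3, `COc1ccc(-n2ccc(=O)c(C(=O)Nc3ccc(Oc4ccnc5c4ccn5C)cc3)n2)cc1`, gives > 60000 nM.

Compound 3 stands at a limit of this assay rather than at a number. Compound 2 also rests at a limit in this assay. Of the three, only compound 1 yields a measured number, 7890 nM. Going by the values given here, the one step that links two measured compounds, a step that the two limits leave unreadable from compound 2 to compound 3, cannot be read in size or direction, since both ends are limits (the limit of > 60000 nM in this assay, at which 2 of the 3 values shown sit).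

Compound 4, `Cn1ccc2c(Oc3ccc(NC(=O)c4nn(-c5ccc(Br)cc5)ccc4=O)cc3)ccnc21`, is to be measured. It differs from compound 3 by bromo in place of methoxy on an aromatic carbon. Among the compounds with values here, the only measured step that touches this place on the ring is the one from compound 2 to compound 3, and it is unreadable, so no measured step sets a direction here. Compound 1 also carries bromo at this position, but it differs from compound 4 elsewhere, and its number stands on its own. Compound 4 is therefore expected to stay close to the weak end, with the step of an at least 1.3-fold lower number from compound 3 to compound 4 (0.12 log units; that floor lies within the scatter) expected to be no more than the scatter. Compound 4 is estimated at 45000 nM, in a range from 12000 nM to 120000 nM.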

Compound 4, half-maximal inhibitory concentration: 16300 nM
Compound 4: the middle estimate sits 2.8-fold (0.44 log units) above what was measured; low and high end bracket the measured number.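

With bromo at this place, this assay gives the first readable result for the shared core carrying methyl on the aromatic nitrogen: the change from 4-methoxyphenyl to 4-bromophenyl gives an at least 3.6-fold lower number from compound 3 to compound 4 (0.56 log units; beyond the scatter), and bromo in place of chloro at the same place gives an at least 3.6-fold lower number from compound 2 to compound 4 (0.56 log units; beyond the scatter). On these data alone, both steps are floors and their full size stays unknown, since compound 2 and compound 3 each rest at a limit of the assay and not at a number: the limit of > 60000 nM in this assay, at which 2 of the 4 values shown sit. Going by these compounds alone, with bromo held constant, methyl in place of hydrogen on the aromatic nitrogen gives a 2.1-fold higher number from compound 1 to compound 4 (0.32 log units; beyond the scatter), the first readable step at that second place.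

As far as these compounds go, the step between compound 2 and compound 3 still cannot be read, so the order of chloro and methoxy at this place remains open, as does how a nitrile, an amine or iodo would compare with bromo there. Also open, from the compounds shown here alone, is whether a longer chain, such as ethyl, on the aromatic nitrogen would carry the number further in the direction set by methyl.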